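A few compounds are considered here, and "the series" means these few. Any claim that something is new, unique, unknown or untested is made for them only; others in the source may bear on it.

Measured compounds in a functional assay on HCT-116 cells (Homo sapiens) for inhibition; on this read-out higher numbers stand for weaker inhibition and lower numbers for stronger inhibition:
compound 1 `CCNC(=O)c1noc(-c2cc(C(C)C)c(O)cc2O)c1-c1cc(CO)no1` gives 13 nM
compound 2 `CCNC(=O)c1noc(-c2cc(C(C)C)c(O)cc2O)c1-c1cc(CN)no1` gives 84 nM
compound 3 `C=CNCc1cc(-c2c(C(=O)NCC)noc2-c2cc(C(C)C)c(O)cc2O)on1` gives 121 nM

Compound 2 stands second highest of the three numbers. Its nearest neighbour is compound 3, and the step of a 1.4-fold higher number from compound 2 to compound 3 (0.16 log units; within the scatter) lies within the scatter; its furthest is compound 1, from which the step of a 6.5-fold higher number from compound 1 to compound 2 (0.81 log units; beyond the scatter) sets it clearly apart.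

Compound 4 `CCNC(=O)c1noc(-c2cc(C(C)C)c(O)cc2O)c1-c1cc(CN(C)C)no1` has not yet been measured. Relative to compound 2 the change is dimethylamino in place of amino on a saturated chain carbon bound to an aromatic carbon. For the measured compounds named here, two measured steps bear on this. The step of a 6.5-fold higher number from compound 1 to compound 2 (0.81 log units; beyond the scatter) concerns the same place but a different exchange, amino in place of hydroxy, and says little about what happens once the amine nitrogen itself carries substituents. The step of a 1.4-fold higher number from compound 2 to compound 3 (0.16 log units; within the scatter) is closer in kind: vinyl in place of hydrogen on the amine nitrogen, and it stays within the scatter. The move from aminomethyl to (dimethylamino)methyl is again substitution on the amine nitrogen, so in this assay a step of a 1.3-fold higher number from compound 2 to compound 4 (0.12 log units; within the scatter) is expected for compound 4, small and probably not beyond the scatter, if anything toward a higher number. For compound 4 the expected value in this assay is therefore 110 nM, with a range from 45 nM to 270 nM.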

Compound 4, half-maximal inhibitory concentration: 92 nM
Beside the measured number, compound 4's estimate is 1.2-fold (0.08 log units) above it; low and high end bracket the measured number.
By their numbers in this assay, from the lowest: compound 1; then compounds 2, 4 and 3 (each within the scatter of the next).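

Notes on the substituent on the saturated chain carbon bound to an aromatic carbon: in this assay the exchange of amino for dimethylamino, which goes from 1 hydrogen-bond donor to 0 hydrogen-bond donors and adds 2 carbon atoms, gives a 1.1-fold higher number from compound 2 to compound 4 (0.04 log units; within the scatter) and so stays within the scatter. The exchange of vinylamino for dimethylamino gives a 1.3-fold lower number from compound 3 to compound 4 (0.12 log units; within the scatter) and also stays within the scatter, so the amino, vinylamino and dimethylamino compounds form one group that cannot be ordered, and substitution on the amine nitrogen has shown no readable effect across these three examples. The exchange of hydroxy for dimethylamino gives a 7.1-fold higher number from compound 1 to compound 4 (0.85 log units; beyond the scatter) and lies beyond the scatter, so all three nitrogen groups now stand apart from the hydroxy compound, with no listed compound going against this, and no measured evidence accounts for that separation.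

Still open, on these data alone, is whether the separation follows the nitrogen itself or the loss of hydroxy, a question that a methoxy group or a carboxylic acid at this place would address. Also open, as far as these compounds go, is whether a larger nitrogen group, such as a morpholine ring or a longer chain on the amine, would stay within the same group of values.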